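The compounds below may be only part of what the source reports. "The series", "measured", "known", "first", "only" and "open" are said of these compounds alone.

Values in a functional assay on MCF7 cells (Homo sapiens) for inhibition, read by MTT assay, with a stated time of 72 h; a lower number here means a stronger inhibitor, a higher number a weaker inhibitor:

- compound 1 `COc1ccc(-c2nnc(SCCCN3CCN(c4nc5ccccc5s4)CC3)o2)cc1`: 171000 nM
- compound 2 `O=[N+]([O-])c1ccc(-c2nnc(SCCCN3CCN(c4nc5ccccc5s4)CC3)o2)cc1`: 118000 nM
- compound 3 `Clc1ccc(-c2nnc(SCCCN3CCN(c4nc5ccccc5s4)CC3)o2)cc1`: 116000 nM

The three compounds share one core and differ only in a single group on an aromatic carbon. Compound 3 cannot be separated from the other two on these numbers. Its comparison with compound 2 is a 1.0-fold lower number from compound 2 to compound 3 (0.01 log units; within the scatter), and its comparison with compound 1 is a 1.5-fold lower number from compound 1 to compound 3 (0.17 log units; within the scatter).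

The next compound, compound 4 `Fc1ccc(-c2nnc(SCCCN3CCN(c4nc5ccccc5s4)CC3)o2)cc1`, carries fluoro in place of chloro on an aromatic carbon, a change from 4-chlorophenyl to 4-fluorophenyl (fluoro in place of chloro on an aromatic carbon). The group sits on a six-membered aromatic ring of carbon only, para to a large group.

For the measured compounds named here, no measured step makes this exact exchange, but three steps exchange a group on that ring. These are a 1.4-fold lower number from compound 1 to compound 2 (0.16 log units; within the scatter), together with the two comparisons already given. None of them goes beyond the scatter, so in this assay no step beyond the scatter is expected here either, and no direction can be claimed. The expected step is a 1.1-fold higher number from compound 3 to compound 4 (0.03 log units; within the scatter). For compound 4 the estimated value is 125000 nM, with an expected range from 75000 nM to 205000 nM.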

Compound 4, half-maximal inhibitory concentration: 84100 nM
For compound 4 the middle estimate is 1.5-fold (0.17 log units) above the measured one, within the range that was stated.
By their numbers in this assay, from the lowest: compounds 4, 3, 2 and 1 (each within the scatter of the next, the first and the last beyond it).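

Fluoro at this place, on an aromatic carbon para to a large group, gives the first step in this assay that clears the scatter: a 2.0-fold lower number from compound 1 to compound 4 (0.31 log units; beyond the scatter). That separation holds only against methoxy, since the exchange from 4-chlorophenyl to 4-fluorophenyl gives a 1.4-fold lower number from compound 3 to compound 4 (0.14 log units; within the scatter), and the exchange for nitro gives a 1.4-fold lower number from compound 2 to compound 4 (0.15 log units; within the scatter), so fluoro cannot be ranked against chloro or nitro, and the halogen exchange itself shows no effect that can be claimed. For the compounds shown here, nothing available bears on why the single step beyond the scatter appears, and the data offer no account of it.

The compounds shown leave open what an amine or a carboxylic acid on that aromatic carbon would do to the number in this assay, and whether a ring with only hydrogen there would fall closer to compound 4 or to compound 1. Going by these compounds, they also keep the rest of the shared core fixed, so it remains open whether the modest spread across these four compounds would persist with a longer chain in place of the present one.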